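Methoxy for fluoro on the aryl thioether of compound 1

A few compounds are considered here, and "the series" means these few. Any claim that something is new, unique, unknown or untested is made for them only; others in the source may bear on it.

Of the compounds shown here, three sharing one core have been measured in a functional assay on MDA-MB-231 cells (Homo sapiens) for inhibition, read by sulforhodamine B assay, with a stated time of 48 h; a lower number here means a stronger inhibitor of growth, a higher number a weaker inhibitor of growth. Compound 1 `Nc1cc(N)c2nc(-c3ccccc3)c(Sc3ccc(F)cc3)nc2c1` gives 17400 nM. Compound 2 `CCOC(=O)[C@H](CCC(=O)O)NC(=O)c1ccc(Oc2nc3cc(N)cc(N)c3nc2-c2ccccc2)cc1` gives 11200 nM, and compound 3 `COc1ccc(CNc2nc3cc(N)cc(N)c3nc2-c2ccccc2)cc1OC` gives 11200 nM. Compound 1 carries the largest number of the three, yet compound 2 and compound 3 each sit within the usual scatter of it, so the three are not separated and no order among them can be read. Among the measured compounds shown here, all three lie in the weak range of this assay, and none of the pairs differs in a single place, so no step between measured compounds is available.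

Compound 4 `COc1ccc(Sc2nc3cc(N)cc(N)c3nc2-c2ccccc2)cc1` is not yet measured. It differs from compound 1 in one place: methoxy in place of fluoro on an aromatic carbon. The change sits on an aromatic carbon of a six-membered aromatic ring of carbon only, para to a large group, on the (4-fluorophenyl)sulfanyl arm, which becomes (4-methoxyphenyl)sulfanyl.

For the measured compounds named here, with no measured step to lean on, the expected step from compound 1 to compound 4 in this assay is a 1.3-fold lower number from compound 1 to compound 4 (0.13 log units; within the scatter), that is, nothing beyond the scatter, in either direction. Compound 4 is therefore estimated at 13000 nM, with a range from 5000 nM to 35000 nM.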

Compound 4, concentration for 50% growth inhibition: < 100000 nM
Compound 4 ended at the assay's limit (the forecaster's own chance of this, stated with the estimate: 10%); the middle value lies beyond the limit too.
By their numbers in this assay, from the lowest: compounds 2, 3 and 1 (each within the scatter of the next).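

In this assay compound 4 gives < 100000 nM, which is a limit of the assay and not a number. No new step can therefore be read between compound 1 and compound 4: the limit of < 100000 nM in this assay, at which 1 of the 4 values shown sits.

The compounds shown leave open whether methoxy in place of fluoro on the (4-fluorophenyl)sulfanyl arm changes growth inhibition at all, and in which direction.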